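Trading a Fluorine for a Sulfonamide: Expected Cell Tolerance

The compounds below may be only part of what the source reports. "The series", "measured", "known", "first", "only" and "open" are said of these compounds alone.

Of the compounds shown here, three built on one shared core have been measured in an ADME assay on LLC-MK2 cells (Macaca mulatta) for cytotoxicity, read by spectrophotometry and crystal violet staining, with a stated time of 4 days; a lower number here means that less compound is tolerated, a higher number that more compound is tolerated. Compound 1 `CC(C)n1ncc2c(C(=O)Nc3ccccc3F)cc(-c3cccnc3)nc21` gives 50000 nM in this assay. Compound 3 `CNS(=O)(=O)c1cccc(NC(=O)c2cc(-c3cccs3)nc3c2cnn3C(C)C)c1` gives 25000 nM in this assay. Compound 2 `CC(C)n1ncc2c(C(=O)Nc3cccc(F)c3)cc(-c3cccs3)nc21` gives only a limit of this assay, > 200000 nM, so for compound 2 there is a boundary rather than a number, as noted by the limit of > 200000 nM in this assay, at which 1 of the 3 values shown sits.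

Compound 4 `CC(C)n1ncc2c(C(=O)Nc3ccccc3S(N)(=O)=O)cc(-c3cccs3)nc21` has not yet been measured. It differs from compound 2 in one place: 2-sulfamoylphenyl in place of 3-fluorophenyl on an amide-type nitrogen. For the measured compounds named here, the only measured step that speaks to this kind of change is an at least 8.0-fold lower number from compound 2 to compound 3 (0.90 log units; beyond the scatter), in which methylsulfamoyl also replaced fluoro on an aromatic carbon and the tolerated concentration fell. A step in the same direction, beyond the scatter, is therefore expected for compound 4, although its exact size is uncertain because the starting point of compound 2 is only a limit, > 200000 nM. Compound 4 is expected to give about 40000 nM in this assay, between 12000 nM and 150000 nM. That estimate corresponds to an expected at least 5.0-fold lower number from compound 2 to compound 4 (0.69 log units; beyond the scatter).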

Compound 4, half-maximal cytotoxic concentration: 25000 nM
Compound 4: the middle estimate sits 1.6-fold (0.20 log units) above what was measured; the range from low to high includes it.
By their numbers in this assay, from the lowest: compounds 3, 4 and 1 (each within the scatter of the next). At a limit, above all of these: compound 2.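

Putting 2-sulfamoylphenyl in place of 3-fluorophenyl on the amide-type nitrogen gives an at least 8.0-fold lower number from compound 2 to compound 4 (0.90 log units; beyond the scatter) in this assay. The earlier drop therefore does not belong to methylsulfamoyl alone: a second sulfonamide-type group, carried on the ring in a different way, also lowers the tolerated concentration beyond the scatter, and compound 3 at 25000 nM and compound 4 at 25000 nM print the same value. The full size of this step stays unknown because compound 2 gives a limit and not a number: the limit of > 200000 nM in this assay, at which 1 of the 4 values shown sits.

Still open, from the compounds shown here alone, is whether the drop follows the sulfonamide-type group itself or would appear with other groups in that place. An amine or a carboxylic acid on the same phenyl ring would help to test this.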